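Alkyne aryl exchange in the amide series: efficacy notes

A few compounds are considered here, and "the series" means these few. Any claim that something is new, unique, unknown or untested is made for them only; others in the source may bear on it.

Compound 1 `C[C@@H](NC(=O)c1ccc(C#Cc2ccccc2F)cn1)C(C)(C)O` gives 60% in a functional assay on HEK293 cells for positive allosteric modulation of metabotropic glutamate receptor 5 (Rattus norvegicus), read by fluorescence and calcium flux; on this read-out lower numbers stand for smaller maximal responses and higher numbers for larger maximal responses. This is the lowest of the two numbers recorded so far, with compound 2 `C[C@@H](NC(=O)c1ccc(C#Cc2ccc(F)cc2)cn1)C(C)(C)O` nearest at 66.2%; the step of a number 6.2 percentage points higher from compound 1 to compound 2 (within the scatter) lies within the scatter, so the two values are read as equal. Compound 3 `C[C@@H](NC(=O)c1ccc(C#Cc2cc(F)ccn2)cn1)C(C)(C)O` remains to be measured. It differs from compound 1 by 4-fluoropyridin-2-yl in place of 2-fluorophenyl on a triple-bonded carbon. Among the measured compounds shown here, the only measured step moves a fluorine within a carbon-only ring and stays within the scatter; no step exchanges the carbon ring for a ring with a hetero atom, so nothing bears directly on this change. For the measured compounds named here, with one within-scatter step as the sole guide, no movement beyond the scatter is expected in this assay. The step expected from this change is no change at the digits printed from compound 1 to compound 3 (within the scatter). Compound 3 is estimated at 60%, with a range from 44% to 78%.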

Compound 3, largest response reached (reported as efficacy), in percent of the reference or control that the assay uses: 66.2%
The estimate for compound 3 lay 6.2 percentage points below the measured number; low and high end bracket the measured number.
By their numbers in this assay, from the lowest: compounds 1, 2 and 3 (each within the scatter of the next).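

In this assay the exchange of 2-fluorophenyl for 4-fluoropyridin-2-yl on a triple-bonded carbon gives a number 6.2 percentage points higher from compound 1 to compound 3 (within the scatter) and the exchange of 4-fluorophenyl for the same group gives no change at the digits printed from compound 2 to compound 3 (within the scatter). The carbon-only ring at this place can thus be replaced by a six-membered aromatic ring with a hetero atom, which adds a hydrogen-bond acceptor, without a step beyond the scatter; the earlier step only moved a fluorine within a carbon-only ring. No supporting measurement bears on this result.

All three compounds lie within the scatter of one another, so no group at this place has yet been seen to shift the maximal response. From the compounds shown here alone, whether an unsubstituted phenyl, a cyclohexyl ring or a pyridine carrying a carboxylic acid or an amine would do so remains open.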